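Extending the amide aryl group of compound 2 to a biphenyl

This account rests on a few compounds, and the source may have more. Where it says the series, first, only, none or still open, it means among the compounds named here.

Compound 2 `COc1cc(OC)cc(C(=O)Nc2cccc(-c3oc4cc(-c5ccc(F)cc5)ccc4c(=O)c3O)c2)c1` gives the lowest number of the two measured in a functional assay on HeLa cells (Homo sapiens) for antiproliferative activity, read by CCK-8 assay, with a stated time of 72 h (on this read-out higher numbers stand for weaker inhibition and lower numbers for stronger inhibition), at 2700 nM; compound 1 `O=C(Nc1cccc(-c2oc3cc(-c4ccc(F)cc4)ccc3c(=O)c2O)c1)c1cccc(F)c1` gives 8780 nM in this assay. Among the compounds with values here, the only measured step, a 3.3-fold lower number from compound 1 to compound 2 (0.51 log units; beyond the scatter), bears on the same position but involves different groups. Compound 3 `O=C(Nc1cccc(-c2oc3cc(-c4ccc(F)cc4)ccc3c(=O)c2O)c1)c1ccc(-c2ccccc2)cc1` differs from compound 2 by 4-phenylphenyl in place of 3,5-dimethoxyphenyl on a carbonyl carbon. Within the data shown here, no measured step covers this particular exchange, so the direction is uncertain. Compound 3 is expected to land near compound 2, with a step of a 1.5-fold higher number from compound 2 to compound 3 (0.17 log units; within the scatter) in this assay. The estimate for compound 3 is 4000 nM, within 1200 nM to 14000 nM.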

Compound 3, half-maximal inhibitory concentration: > 100000 nM
Compound 3: only a limit was reported (the forecaster's own chance of this, stated with the estimate: 5%); middle value at least 25-fold (1.39 log units) away from the limit.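

Where the earlier exchange on this carbonyl carbon was modest, 4-phenylphenyl brings a large change, with an at least 37-fold higher number from compound 2 to compound 3 (1.56 log units; beyond the scatter) and an at least 11-fold higher number from compound 1 to compound 3 (1.05 log units; beyond the scatter) in this assay. The reading for compound 3 is a limit and not a number: the limit of > 100000 nM in this assay, at which 1 of the 3 values shown sits. This place therefore does not accept every aryl group equally, and the result depends strongly on which one sits on the carbonyl carbon. Going by these compounds, whether a plain phenyl, a 4-methoxyphenyl or a cyclohexyl group here would behave like compound 2 or like compound 3 remains open.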